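Swapping the sulfonyl aryl group in compound 1

The compounds below may be only part of what the source reports. "The series", "measured", "known", "first", "only" and "open" are said of these compounds alone.

Compound 1 `COc1ccc(S(=O)(=O)c2cnc3c(F)cccc3c2-c2ccc(Cl)cc2)cc1` holds the lower of the two numbers measured in an ADME assay on microsomes from liver (Homo sapiens) for metabolic stability, tested at 2.5 uM (a lower number here means slower removal, a higher number faster removal of the compound), where compound 1 gives 1.05 mL/min. Among the compounds with values here, its only measured neighbour is compound 2 `COc1ccc(S(=O)(=O)c2cnc3c(F)cccc3c2-c2cccc(OC)c2)cc1`, which carries a 3-methoxyphenyl in place of 4-chlorophenyl on an aromatic carbon; in this assay compound 2 gives 2.87 mL/min, a step of a 2.7-fold higher number from compound 1 to compound 2 (0.44 log units; beyond the scatter). Compound 3 `N#Cc1cccc(S(=O)(=O)c2cnc3c(F)cccc3c2-c2ccc(Cl)cc2)c1` is not yet measured. It differs from compound 1 at a different place: 3-cyanophenyl in place of 4-methoxyphenyl on a sulfonyl sulfur. Within the data shown here, the one measured step in this set touched the aryl group on the aromatic carbon and left the sulfonyl sulfur untouched, so no measured step bears on the present exchange. With nothing to point in either direction, a step no larger than the scatter is expected, a 1.0-fold higher number from compound 1 to compound 3 (0.02 log units; within the scatter). The value expected for compound 3 in this assay is 1.1 mL/min, with a range from 0.45 mL/min to 2.8 mL/min, the range kept wide because a 2.7-fold higher number from compound 1 to compound 2 (0.44 log units; beyond the scatter) shows that a single change on an outer ring can move the number beyond the scatter.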

Compound 3, intrinsic clearance in a liver preparation (reported as CLH), per the amount of preparation that the assay uses: 0.08 mL/min
Compound 3: the middle estimate sits 14-fold (1.14 log units) above what was measured, outside the stated range (below it).
By their numbers in this assay, from the lowest: compound 3; then compound 1; then compound 2.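

In this assay the exchange of 4-methoxyphenyl for 3-cyanophenyl on the sulfonyl sulfur gives a 13-fold lower number from compound 1 to compound 3 (1.12 log units; beyond the scatter) and so places compound 3 lowest of the three numbers. This shows that the sulfonyl aryl group is not a silent position: the step is labelled large and runs the opposite way to the modest step on the aromatic carbon, a 2.7-fold higher number from compound 1 to compound 2 (0.44 log units; beyond the scatter) in the same assay. The change is also a close one by simple count, since the leaving and entering groups each hold the same number of heavy atoms and hydrogen-bond acceptors and carry no net charge, and nothing measured here accounts for the size of the step.

From the compounds shown here alone, the exchange alters both the group on the ring and the place named for it, so it remains open whether the nitrile or the loss of 4-methoxyphenyl carries the step, and 4-cyanophenyl or 3-methoxyphenyl on the sulfonyl sulfur would separate the two. Going by these compounds, it also remains open whether the step would hold with 3-methoxyphenyl on the aromatic carbon, or how an amine or a carboxylic acid on the sulfonyl aryl ring would read.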